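The source may hold more compounds than are shown below. What is called first, only, known or untested is meant among the compounds shown, and "the series" means these compounds.

Measured so far:
compound 1 `COC(=O)C1=CN(C(C)C)C(=O)[C@@H]2C(CN3CCN(Cc4ccc([N+](=O)[O-])cc4)CC3)=CC[C@H]12` — 74.3%
compound 2 `COC(=O)C1=CNC(=O)[C@@H]2C(CO)=CC[C@H]12` — 69.4%
compound 3 `COC(=O)C1=CN(C)C(=O)[C@@H]2C(CN3CCN(Cc4cccc(C(F)(F)F)c4)CC3)=CC[C@H]12` — 72.5%

In a functional assay on Cortical neurone cells (Rattus norvegicus, strain Sprague-Dawley), read by MTT assay, with stated times of 24 h and 2 h, tested at 1 uM (a higher number here means a stronger effect of the compound at the concentration tested, a lower number a weaker effect), compound 1 gives 74.3%, the highest of the three numbers; compound 3 sits nearest and compound 2 furthest, and both gaps fall within the usual scatter, so no order among the three can be read from them. Compound 4 `COC(=O)C1=CN(C(C)C)C(=O)[C@@H]2C(CN3CCN(Cc4cccc(OC)c4)CC3)=CC[C@H]12` has not yet been measured. It differs from compound 1 in one place: 3-methoxyphenyl in place of 4-nitrophenyl on a saturated chain carbon bound to an amine nitrogen in a ring. Within the data shown here, no step between two measured compounds is known for this change, so nothing comparable is at hand. Among the measured compounds shown here, the three numbers so far hardly move across rather different structures, and on that basis the expected step is a number 2.3 percentage points lower from compound 1 to compound 4 (within the scatter). Compound 4 is therefore estimated at 72%, in a range from 62% to 82%.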

Compound 4, a percentage reported as activity, at one concentration (the size of the read-out at that concentration, not a potency): 62.1%
For compound 4 the middle estimate is 9.9 percentage points above the measured one; low and high end bracket the measured number.
By their numbers in this assay, from the lowest: compounds 4, 2, 3 and 1 (each within the scatter of the next, the first and the last beyond it).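

In this assay, among these compounds, 3-methoxyphenyl in place of 4-nitrophenyl on a saturated chain carbon bound to an amine nitrogen in a ring gives a number 12.2 percentage points lower from compound 1 to compound 4 (beyond the scatter) as the first reading of a change in one place. Among the compounds shown here, the aryl group at this place therefore bears on the read-out, which the earlier compounds, differing in more than one place, could not show. No measurement on hand accounts for the step.

As far as these compounds go, whether the step follows from the group itself or from where it sits on the ring remains open. 3-Nitrophenyl, 4-methoxyphenyl and unsubstituted phenyl at this place would separate the two.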